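The source may report more compounds than this note shows. Statements on the series, on what has been measured and on what is new or still open speak of the compounds shown alone.

Working notes on the series in a functional assay on Huh-7 cells (Homo sapiens) for inhibition, read by CCK-8 assay, with a stated time of 72 h; on this read-out higher numbers stand for weaker inhibition and lower numbers for stronger inhibition: compound 1 `O=C(/C=C/c1cccnc1)NCCCCCCc1ccc(S(=O)(=O)Nc2ccccc2)cc1` gives 112 nM, compound 2 `O=C(/C=C/c1cccnc1)NCCCc1cccc(S(=O)(=O)Nc2ccccc2)c1` gives 384 nM, and compound 3 `Cc1ccc(NS(=O)(=O)c2cccc(CCCCCCNC(=O)/C=C/c3cccnc3)c2)cc1` gives 6.92 nM. Compound 3 has the lowest number of the three, beyond the scatter from both others. Compound 4 `CC(C)(C)c1ccc(NS(=O)(=O)c2cccc(CCCCCCNC(=O)/C=C/c3cccnc3)c2)cc1` carries tert-butyl in place of methyl on an aromatic carbon, para to a large group (tert-butyl in place of methyl on an aromatic carbon). Among the measured compounds shown here, no measured pair differs in one place, so this change has no direct precedent. In this assay a modest rise toward weaker inhibition is expected, and the estimated move is a 2.2-fold higher number from compound 3 to compound 4 (0.34 log units; beyond the scatter), close to the edge of the scatter. Compound 4 is estimated at 15 nM, with an expected range of 4 nM to 60 nM.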

Compound 4, half-maximal inhibitory concentration: 163 nM
For compound 4 the middle estimate is 11-fold (1.04 log units) below the measured one, and the stated range ends below it.
By their numbers in this assay, from the lowest: compound 3; then compounds 1 and 4 (each within the scatter of the next); then compound 2.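

In this assay, among the compounds shown here, tert-butyl in place of methyl gives a 24-fold higher number from compound 3 to compound 4 (1.37 log units; beyond the scatter) and is the first step that differs in one place. The aromatic carbon para to a large group is therefore not a neutral site: replacing a group of 1 heavy atom with one of 4 is enough to produce a large step in this read-out. Nothing at hand accounts for the size of this step.

Going by these compounds, with only methyl and tert-butyl at this carbon, the shape of the trend remains open, and ethyl or isopropyl would show where between them the change sets in. Also open, on these data alone, is how hydrogen or chlorine there would compare with methyl.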